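The source may hold more compounds than are shown below. What is called first, only, known or untested is meant among the compounds shown, and "the series" means these compounds.

Measured so far in a functional assay on SW-620 cells (Homo sapiens) for antiproliferative activity, read by MTT assay, with a stated time of 72 h; on this read-out higher numbers stand for weaker inhibition and lower numbers for stronger inhibition:
- compound 1, `O=C1O/C(=C\Cn2cc(-c3cc(F)cc(F)c3)nn2)C(OCc2ccccc2)=C1OCc1ccccc1`: > 100000 nM
- compound 2, `CCCCc1cn(C[C@H](O)[C@H]2OC(=O)C(OCc3ccccc3)=C2OCc2ccccc2)nn1`: 47500 nM

The value for compound 1 is a limit of the assay, not a number; compound 1 sits at the limit of > 100000 nM in this assay, at which 1 of the 2 values shown sits, so only the weak end of its activity is fixed. Among the measured compounds shown here, compound 2 is the one member of the pair with a measured number, and no step between the two is given, so their values can only be read side by side: compound 2 shows measurable but weak inhibition, while compound 1 shows none within the range tested.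

Compound 3, `COc1ccccc1-c1cn(C/C=C2\OC(=O)C(OCc3ccccc3)=C2OCc2ccccc2)nn1`, shares the core of compound 1 and differs from it in one place: 2-methoxyphenyl in place of 3,5-difluorophenyl on an aromatic carbon.

For the measured compounds named here, no measured step of this kind is available, so the size of the change is uncertain. A step from compound 1 to compound 3 is expected to be small, if any, most likely staying within the scatter, and the estimated step is an at least 1.4-fold lower number from compound 1 to compound 3 (0.15 log units; that floor lies within the scatter). Compound 3 is expected to come out near 70000 nM, with a range from 20000 nM to 250000 nM.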

Compound 3, half-maximal inhibitory concentration: > 100000 nM
Compound 3 ended at the assay's limit; the forecaster's own chance of this, stated with the estimate: 50%; middle value at least 1.4-fold (0.15 log units) from the limit.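

In this assay compound 3 gives > 100000 nM, which is a limit of the assay and not a number. Compound 1 also sits at this limit, so no step can be read between compound 1 and compound 3: the limit of > 100000 nM in this assay, at which 2 of the 3 values shown sit.

The compounds shown leave open whether 2-methoxyphenyl in place of 3,5-difluorophenyl changes inhibition at all.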